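A few compounds are considered here, and "the series" means these few. Any claim that something is new, unique, unknown or untested is made for them only; others in the source may bear on it.

Working notes on the series. Compound 1 `COc1cc(/C=C/C(=O)c2cccc(NC(=O)c3cccs3)c2)ccc1O`, compound 2 `COc1cc(/C=C/C(=O)c2cccc(NC(=O)c3ccc(Cl)cc3)c2)ccc1O` and compound 3 `CCCC(=O)Nc1cccc(C(=O)/C=C/c2ccc(O)c(OC)c2)c1` share one core and differ only in the group on a carbonyl carbon whose other neighbour is an amide-type nitrogen. In a functional assay on HUVEC cells (Homo sapiens) for inhibition, tested at 10 ug/mL (a higher number here means a stronger effect of the compound at the concentration tested, a lower number a weaker effect), compound 1 gives 90%, compound 2 gives 66% and compound 3 gives 87%. Compound 2 stands lowest of the three measured numbers; the nearest is compound 3 and the widest gap is to compound 1. Going from thiophen-2-yl to 4-chlorophenyl gives a number 24 percentage points lower from compound 1 to compound 2 (beyond the scatter), going from 4-chlorophenyl to propyl gives a number 21 percentage points higher from compound 2 to compound 3 (beyond the scatter), and a number 3 percentage points lower from compound 1 to compound 3 (within the scatter) lies within the scatter, so thiophen-2-yl and propyl sit together here.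

Compound 4 `COc1cc(/C=C/C(=O)c2cccc(NC(C)=O)c2)ccc1O` is the unmeasured member; its change from compound 2 is methyl in place of 4-chlorophenyl on a carbonyl carbon. The step bearing most on it is a number 21 percentage points higher from compound 2 to compound 3 (beyond the scatter), propyl and methyl both being chains without a ring, and the thiophen-2-yl comparison points the same way. A rise beyond the scatter is therefore expected for compound 4 in this assay, of about a number 19 percentage points higher from compound 2 to compound 4 (beyond the scatter). For compound 4 the estimated value is 85%, within a range of 70% to 95%.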

Compound 4, a percentage reported as inhibition, at one concentration (the size of the read-out at that concentration, not a potency): 32%
Compound 4: middle estimate off by 53 percentage points, on the high side; the measured number lies below the stated range.
By their numbers in this assay, from the lowest: compound 4; then compound 2; then compounds 3 and 1 (each within the scatter of the next).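

In this assay the absence of a ring does not by itself keep the number high on this carbonyl carbon: hydrogen in place of ethyl on a saturated chain carbon bound to a carbonyl carbon, which turns propyl into methyl, gives a number 55 percentage points lower from compound 3 to compound 4 (beyond the scatter) and so sets the two ring-free groups far apart. Methyl also falls under both ring-bearing groups, with a number 34 percentage points lower from compound 2 to compound 4 (beyond the scatter) against 4-chlorophenyl and a number 58 percentage points lower from compound 1 to compound 4 (beyond the scatter) against thiophen-2-yl, so among these four compounds the order follows neither the presence of a ring nor its absence. Nothing available explains why the acetyl compound stands so low.

The compounds shown leave open where the number climbs along the chain, which an ethyl group on the same carbonyl carbon would help to place, and whether a longer chain such as pentyl holds it up. They also leave open whether the gap between 4-chlorophenyl and thiophen-2-yl belongs to the chlorine or to the ring, which an unsubstituted phenyl group would separate.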